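A few compounds are considered here, and "the series" means these few. Any claim that something is new, unique, unknown or untested is made for them only; others in the source may bear on it.

Measured so far:
- compound 1, `O=C1OCc2cc(N(Cc3ccc(C4CCCCC4)cn3)C(=O)[C@H]3CCN3S(=O)(=O)c3c(F)c(F)c(F)c(F)c3F)ccc21`, in an ADME assay on MCF-10A cells (Homo sapiens) for cytotoxicity, with a stated time of 72 h (a higher number here means that more compound is needed for the effect, a lower number that less compound is needed), compound 1 gives 4600 nM
- compound 2, `Cn1ccc2cc(N(Cc3ccc(C4CCCCC4)cn3)C(=O)[C@H]3CCN3S(=O)(=O)c3c(F)c(F)c(F)c(F)c3F)ccc2c1=O`, in this assay compound 2 gives 4400 nM

The two numbers sit within the scatter of each other, so compound 2 cannot be placed as either stronger or weaker than compound 1. Among the compounds with values here, the only measured step, a 1.0-fold lower number from compound 1 to compound 2 (0.02 log units; within the scatter), swaps one ring system on the amide-type nitrogen for another without any effect beyond the scatter.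

Compound 3, `O=C([C@H]1CCN1S(=O)(=O)c1c(F)c(F)c(F)c(F)c1F)N(Cc1ccc(C2CCCCC2)cn1)c1cc2[nH]ncc2cc1F`, is not yet measured. It differs from compound 2 at the same position: a group of 10 heavy atoms (7 carbon, 2 nitrogen, 1 fluorine; one five-membered aromatic ring with 2 hetero atoms, one six-membered aromatic ring of carbon only) in place of a group of 12 heavy atoms (10 carbon, 1 nitrogen, 1 oxygen; one six-membered aromatic ring of carbon only, one six-membered aromatic ring with 1 hetero atom), on an amide-type nitrogen.

The step from compound 1 to compound 2 is the only one that bears on this change, and it was flat; but the group entering here is of a different kind, so the guidance is weak. The expectation is therefore a step of about a 1.0-fold higher number from compound 2 to compound 3 (0.01 log units; within the scatter), none beyond the scatter, with a wide range. Compound 3 is estimated at 4500 nM, between 1500 nM and 14000 nM.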

Compound 3, half-maximal effective concentration: 4900 nM
The estimate for compound 3 lay 1.1-fold (0.04 log units) below the measured number, and the stated range covers the measured number.
By their numbers in this assay, from the lowest: compounds 2, 1 and 3 (each within the scatter of the next).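

Within this assay the entry of 5-fluoro-1H-indazol-6-yl on the amide-type nitrogen gives a 1.1-fold higher number from compound 2 to compound 3 (0.05 log units; within the scatter) and a 1.1-fold higher number from compound 1 to compound 3 (0.03 log units; within the scatter) and so produces no change that can be told from the scatter. The flat result now extends to a third group, and this one differs from the two before it by carrying a fluorine and a hydrogen-bond donor, so neither feature shifts the number in this set of compounds. No available evidence accounts for this flatness.

On these data alone, all three groups contain two rings, so it remains open whether a single benzene ring would also leave the number unchanged. As far as these compounds go, it is equally open whether a group bearing an amine or a carboxylic acid at this place would move the number beyond the scatter.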